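Swapping trifluoromethyl for cyano on the aniline ring

The source may hold more compounds than are shown below. What is called first, only, known or untested is meant among the compounds shown, and "the series" means these compounds.

Compound 3 `Cc1ccccc1C(=O)c1cnc(Nc2cccc(C(F)(F)F)c2)s1` is measured in an assay for inhibition of Neuropeptide Y receptor type 5 (Mus musculus) (a higher number here means a weaker inhibitor, a lower number a stronger inhibitor), at 63 nM. That places it second highest of the three numbers: compound 1 `N#Cc1cccc(Nc2ncc(C(=O)c3ccccc3F)s2)c1` gives 19 nM, and compound 2 `COc1ccc(C(=O)c2cnc(Nc3cccc(C#N)c3)s2)cc1` gives 2230 nM. For the measured compounds named here, the only single-point step seen so far, a 120-fold higher number from compound 1 to compound 2 (2.07 log units; beyond the scatter), concerns the ketone side of the shared core, not the aniline side. Compound 4 `Cc1ccccc1C(=O)c1cnc(Nc2cccc(C#N)c2)s1` arises from compound 3 by cyano in place of trifluoromethyl on an aromatic carbon. Going by the values given here, no measured pair isolates this change, so no step bears on it directly; compound 1, which carries the cyano group, differs from compound 3 in two places. A modest step is therefore expected, a 1.6-fold lower number from compound 3 to compound 4 (0.20 log units; within the scatter), and compound 4 is estimated at 40 nM, within 12 nM to 130 nM.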

Compound 4, half-maximal inhibitory concentration: 4.2 nM
Beside the measured number, compound 4's estimate is 9.5-fold (0.98 log units) above it; the whole stated range lies above it.
By their numbers in this assay, from the lowest: compound 4; then compound 1; then compound 3; then compound 2.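

On the aniline ring, cyano in place of trifluoromethyl proves to be a large change on its own (a 15-fold lower number from compound 3 to compound 4 (1.18 log units; beyond the scatter)), which makes compound 4 the strongest inhibitor of the four. With cyano held fixed, methyl in place of fluoro on the ketone's aromatic ring gives a smaller step (a 4.5-fold lower number from compound 1 to compound 4 (0.66 log units; beyond the scatter)), while 2-methylphenyl in place of 4-methoxyphenyl gives the largest (a 530-fold lower number from compound 2 to compound 4 (2.73 log units; beyond the scatter)). No measurement here explains these differences.

As far as these compounds go, whether the benefit of cyano carries over to other ketone groups remains open. So does the effect of an amine or a carboxylic acid at this aromatic carbon.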